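Methoxy on the Aromatic Ring of a Thiosemicarbazone Pair

This account rests on a few compounds, and the source may have more. Where it says the series, first, only, none or still open, it means among the compounds named here.

Four compounds built on closely related cores are considered here. Compound 1 `CC1=CC[C@H](C(C)(C)NC(=S)N/N=C/c2ccccc2)CC1` is measured in a functional assay on UACC-62 cells (Homo sapiens) for inhibition, read by sulforhodamine B assay, with a stated time of 48 h (on this read-out higher numbers stand for weaker inhibition of growth and lower numbers for stronger inhibition of growth), and compound 1 gives only a limit of the assay, > 100000 nM. Compound 2 `COc1ccc(/C=N/NC(=S)NC(C)(C)[C@H]2CC=C(C)CC2)cc1` carries one change relative to compound 1, namely (methoxy in place of hydrogen on an aromatic carbon). In this assay compound 2 gives 70400 nM. The step of an at least 1.4-fold lower number from compound 1 to compound 2 (0.15 log units; that floor lies within the scatter) is therefore small, and its size is set by the fact that compound 1 sits at the limit of > 100000 nM in this assay, at which 2 of the 3 values shown sit, so the true change may be larger than the floor shown.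

Compound 3 `CC1=CC[C@H](C(C)(C)NC(=S)N/N=C(\C)c2ccccc2)CC1` rests on a second core; the difference between the two cores is not broken down here. In this assay compound 3 gives only a limit of the assay, > 100000 nM. Compound 4 `COc1ccc(/C(C)=N/NC(=S)NC(C)(C)[C@H]2CC=C(C)CC2)cc1` has not yet been measured; it differs from compound 3 by methoxy in place of hydrogen on an aromatic carbon, the same change as that from compound 1 to compound 2, made at the same place.

Because the measured version of this change, an at least 1.4-fold lower number from compound 1 to compound 2 (0.15 log units; that floor lies within the scatter), stays within the usual scatter and starts from a limit, the expected step of an at least 1.1-fold lower number from compound 3 to compound 4 (0.04 log units; that floor lies within the scatter) is taken to be of similar modest size. Compound 4 is accordingly estimated at 90000 nM, with a range from 45000 nM to 200000 nM and a real chance that the assay again returns only a limit.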

Compound 4, concentration for total growth inhibition: > 100000 nM
Compound 4: no number, only a limit (the forecaster's own chance of this, stated with the estimate: 50%); middle value at least 1.1-fold (0.04 log units) from the limit.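

In this assay compound 4 gives only a limit of the assay, > 100000 nM. Going by these compounds alone, compound 3 also gives a limit, so no step from compound 3 to compound 4 can be read, because both compounds sit at the same limit: the limit of > 100000 nM in this assay, at which 3 of the 4 values shown sit.

The compounds shown leave open whether methoxy in place of hydrogen changes growth inhibition on the core of compound 3, and how far the true values of compound 3 and compound 4 lie past that limit.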